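The source may report more compounds than this note shows. Statements on the series, on what has been measured and on what is new or still open speak of the compounds shown alone.

Measured so far:
- compound 1, `CCCCN(Cc1cn2c(N3CCN(C)CC3)cccc2n1)[C@H]1CCCc2cccnc21`: 5300 nM
- compound 2, `CN1CCN(c2cccc3nc(CN(Cc4ccccc4)[C@H]4CCCc5cccnc54)cn23)CC1`: 9300 nM
- compound 3, `CC(C)N1CCN(c2cccc3nc(CN(C)[C@H]4CCCc5cccnc54)cn23)CC1`: 7100 nM

In an ADME assay on HOS cells (Homo sapiens) for cytotoxicity (a lower number here means that less compound is tolerated, a higher number that more compound is tolerated), compound 2 gives the highest of the three numbers, but its distance to compound 3, which gives 7100 nM, and to compound 1, which gives 5300 nM, lies within the scatter, so no order among the three can be read from these numbers.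

Compound 4, `CC(C)CN(Cc1cn2c(N3CCN(C)CC3)cccc2n1)[C@H]1CCCc2cccnc21`, has not yet been measured in this assay. It differs from compound 2 by isopropyl in place of phenyl on a saturated chain carbon bound to an amine nitrogen.

Going by the values given here, one measured step bears on this change. From compound 1 to compound 2 the replacement of propyl by phenyl at the same position gave a 1.8-fold higher number from compound 1 to compound 2 (0.24 log units; within the scatter), a step that stays within the scatter. The change from compound 2 to compound 4 runs the other way, putting a small saturated group back in place of the phenyl, and the nearest comparison is therefore compound 1 with 5300 nM. The shared core and the remaining substituents are unchanged between compound 2 and compound 4.

Compound 4 is therefore expected to come out close to compound 2, with at most a small shift toward the number of compound 1, within the scatter: a 1.4-fold lower number from compound 2 to compound 4 (0.16 log units; within the scatter). For compound 4 the estimate in this assay is 6500 nM, with a range from 3000 nM to 14000 nM.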

Compound 4, half-maximal cytotoxic concentration: 20000 nM
Estimate against measurement, compound 4: 3.1-fold (0.49 log units) below, and the stated range ends below it.
By their numbers in this assay, from the lowest: compounds 1, 3 and 2 (each within the scatter of the next); then compound 4.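

In this assay, the position on a saturated chain carbon bound to an amine nitrogen now gives steps beyond the scatter, though both are modest: isopropyl in place of phenyl gives a 2.2-fold higher number from compound 2 to compound 4 (0.33 log units; beyond the scatter), and isopropyl in place of propyl gives a 3.8-fold higher number from compound 1 to compound 4 (0.58 log units; beyond the scatter). Going by these compounds alone, the only earlier step at this position, a 1.8-fold higher number from compound 1 to compound 2 (0.24 log units; within the scatter), could not separate the saturated propyl from the aromatic phenyl, whereas compound 4 now stands apart from both, so saturated groups at this position do not all read alike. Nothing on hand accounts for the difference between isopropyl and propyl.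

The series rests on a single branched group at this position, so one value for compound 4 cannot show whether branching itself goes with the higher number or whether this holds only for isopropyl. Also open, on these data alone, is how a tert-butyl, a cyclohexyl, a longer chain or a chain ending in a carboxylic acid or an amine would read in this assay against compound 4.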